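Thiophen-2-yl in place of phenyl on the shared core

The source may hold more compounds than are shown below. What is called first, only, known or untested is meant among the compounds shown, and "the series" means these compounds.

In a functional assay on KB cells (Homo sapiens) for inhibition, with a stated time of 72 h (on this read-out higher numbers stand for weaker inhibition and lower numbers for stronger inhibition), compound 3 (`COc1ccc(S(=O)(=O)N2CCc3cccc(-c4ccccc4)c32)cc1`) gives 120 nM. Compound 2 (`COc1ccc(S(=O)(=O)N2CCc3cccc(-c4ccncc4)c32)cc1`) gives 96 nM, within the scatter of compound 3, while compound 1 (`COc1ccc(S(=O)(=O)N2CCc3cccc(-c4ccc(F)c(F)c4)c32)cc1`) gives 45 nM. Compound 4 (`COc1ccc(S(=O)(=O)N2CCc3cccc(-c4cccs4)c32)cc1`) carries thiophen-2-yl in place of phenyl on an aromatic carbon. Two measured steps at this same place bear on the change. The first, a 1.3-fold higher number from compound 2 to compound 3 (0.10 log units; within the scatter), is small, and the second, a 2.7-fold higher number from compound 1 to compound 3 (0.43 log units; beyond the scatter), is modest. Neither involves a five-membered ring, so the guidance is indirect. No step beyond the scatter is therefore expected in this assay. The expected step is a 1.2-fold lower number from compound 3 to compound 4 (0.08 log units; within the scatter). Compound 4 is estimated at 100 nM, with an expected range of 45 nM to 220 nM.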

Compound 4, half-maximal inhibitory concentration: 215 nM
Estimate against measurement, compound 4: 2.2-fold (0.33 log units) below; the measured number falls inside the stated range.
By their numbers in this assay, from the lowest: compound 1; then compounds 2, 3 and 4 (each within the scatter of the next, the first and the last beyond it).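

In (this assay) the five-membered thiophen-2-yl stays within the scatter of phenyl (a 1.8-fold higher number from compound 3 to compound 4 (0.25 log units; within the scatter)) but separates from pyridin-4-yl (a 2.2-fold higher number from compound 2 to compound 4 (0.35 log units; beyond the scatter)), although phenyl and pyridin-4-yl themselves lie within the scatter of each other. The largest step at this position is now the one from 3,4-difluorophenyl (a 4.8-fold higher number from compound 1 to compound 4 (0.68 log units; beyond the scatter)), which keeps that group at the low end of the series. Nothing measured here accounts for these steps. The compounds shown leave open how an amine, a carboxylic acid or a furan ring would behave on this aromatic carbon.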